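The source may hold more compounds than are shown below. What is called first, only, known or untested is meant among the compounds shown, and "the series" means these compounds.

Measured compounds in a functional assay on U2OS cells for antagonist activity at proto-oncogene Wnt-3 (Homo sapiens), read by a luciferase reporter, with a stated time of 18 h; on this read-out higher numbers stand for an effect only at larger amounts of compound and lower numbers for an effect already at smaller amounts:
compound 1, `O=C(CN1CCCC1)N1CCC(NS(=O)(=O)c2cc(S(=O)(=O)c3ccccc3)ccc2C(F)(F)F)CC1`, gives 190 nM
compound 2, `O=C([C@@H]1CCCN1C(=O)N1CCOCC1)N1CCC(NS(=O)(=O)c2cc(S(=O)(=O)c3ccccc3)ccc2C(F)(F)F)CC1`, gives 280 nM
compound 3, `CN1CCC[C@H]1C(=O)N1CCC(NS(=O)(=O)c2cc(S(=O)(=O)c3ccccc3)ccc2C(F)(F)F)CC1`, gives 230 nM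

Compound 3 sits second highest of the three numbers, yet a 1.2-fold higher number from compound 1 to compound 3 (0.08 log units; within the scatter) and a 1.2-fold lower number from compound 2 to compound 3 (0.09 log units; within the scatter) both lie within the scatter, so the three compounds are not separated from one another. Compound 4, `O=C([C@@H]1CCCN1Cc1ccccc1)N1CCC(NS(=O)(=O)c2cc(S(=O)(=O)c3ccccc3)ccc2C(F)(F)F)CC1`, differs from compound 3 by phenyl in place of hydrogen on a saturated chain carbon bound to an amine nitrogen in a ring. Going by the values given here, no measured step swaps hydrogen for phenyl at this place; the two measured steps that reach compound 3 are the nearest guides, and both were small. A step within the scatter is therefore expected, a 1.1-fold higher number from compound 3 to compound 4 (0.05 log units; within the scatter), with no clear direction. Compound 4 is expected to give 260 nM in this assay, with a range from 100 nM to 700 nM.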

Compound 4, half-maximal effective concentration: 720 nM
Compound 4: the middle estimate sits 2.8-fold (0.44 log units) below what was measured; the whole stated range lies below it.
By their numbers in this assay, from the lowest: compounds 1, 3 and 2 (each within the scatter of the next); then compound 4.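

On the amine nitrogen in a ring, earlier changes left the number within the scatter, but replacing the methyl of compound 3 with benzyl gives a 3.1-fold higher number from compound 3 to compound 4 (0.50 log units; beyond the scatter) in this assay. The steps of a 2.6-fold higher number from compound 2 to compound 4 (0.41 log units; beyond the scatter) and a 3.8-fold higher number from compound 1 to compound 4 (0.58 log units; beyond the scatter) point the same way, so compound 4 needs a larger amount for its effect than each earlier compound. No measurement shown here gives a reason for this loss. From the compounds shown here alone, it remains open whether the loss follows from the phenyl ring itself or from added carbon atoms generally. A cyclohexylmethyl group or a simple ethyl group on that nitrogen would help separate the two.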